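A few compounds are considered here, and "the series" means these few. Any claim that something is new, unique, unknown or untested is made for them only; others in the source may bear on it.

Measured compounds:
compound 1 `O=C(C1CCC(F)(F)CC1)N1CC(c2nc(-c3cccc(F)c3)no2)C1`, in an assay on HEK293 cells for positive allosteric modulation of metabotropic glutamate receptor 5 (Homo sapiens), read by FLIPR (on this read-out higher numbers stand for an effect only at larger amounts of compound and lower numbers for an effect already at smaller amounts), compound 1 gives 520 nM
compound 2 `Cc1cccc(-c2noc(C3CN(S(=O)(=O)c4cccc(C)c4)C3)n2)c1`, for compound 2 this assay reports only a limit, > 10000 nM
compound 3 `CC1CCCC(C(=O)N2CC(c3nc(-c4cccc(Cl)c4)no3)C2)C1`, in this assay compound 3 gives 410 nM

Three compounds share a common core and differ in the group attached to its nitrogen and in the substituent on the aromatic ring. Compound 3 and compound 1 give numbers that sit within the usual scatter of each other, so neither can be called the more potent of the two. Among the measured compounds shown here, the remaining value belongs to compound 2, and it is a limit of the assay rather than a measured number; no step between compounds that differ in only one place is available.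

Compound 4 `O=C(C1CCC2(CCC2)CC1)N1CC(c2nc(-c3cccc(Cl)c3)no2)C1` has not yet been measured. It differs from compound 3 in one place: a group of 9 heavy atoms (9 carbon; one four-membered non-aromatic ring of carbon only, one six-membered non-aromatic ring of carbon only) in place of a group of 7 heavy atoms (7 carbon; one six-membered non-aromatic ring of carbon only), on a carbonyl carbon. Without a measured step of this kind, the expectation can rest only on the closeness of compound 3 and compound 1 despite their different acyl groups. The step of a 1.2-fold higher number from compound 3 to compound 4 (0.09 log units; within the scatter) is expected to stay within the scatter, with no clear direction. For compound 4 the estimate in this assay is 500 nM, within a range from 150 nM to 1700 nM.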

Compound 4, half-maximal effective concentration: 1100 nM
Compound 4: the middle estimate sits 2.2-fold (0.34 log units) below what was measured; measured number inside the range.
By their numbers in this assay, from the lowest: compounds 3 and 1 (each within the scatter of the next); then compound 4. At a limit, above all of these: compound 2.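

In this assay, among the compounds shown here, this is the first step in which only the group on the carbonyl carbon changes while the rest of the molecule stays the same. Replacing 3-methylcyclohexyl with a larger group that has one four-membered and one six-membered carbon ring gives a 2.7-fold higher number from compound 3 to compound 4 (0.43 log units; beyond the scatter), so the number at this position does respond to the choice of group, though the step is modest and compound 4 still gives a measured number rather than a limit. Nothing measured here accounts for this change.

A single step cannot separate the effect of gaining the four-membered ring from that of losing the methyl group, and a plain cyclohexyl group on the same carbonyl carbon would be the direct way to tell the two apart. Also open is how the number would move with a ring carrying an amine or a carboxylic acid at this place, as every group on the carbonyl carbon shown here is built of carbon alone, apart from the two fluorines of compound 1.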